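This account rests on a few compounds, and the source may have more. Where it says the series, first, only, none or still open, it means among the compounds named here.

Of the compounds shown here, two with a shared core have numbers so far. In a functional assay on MCF7 cells (Homo sapiens) for cytotoxicity (a lower number here means a stronger inhibitor, a higher number a weaker inhibitor), compound 1 `O=C(CCCCCCC(=O)Nc1nc2ccccc2s1)NO` gives 6.61 ug/mL and compound 2 `O=C(CCCCCCC(=O)Nc1nc2ccc([N+](=O)[O-])cc2s1)NO` gives 3.83 ug/mL as its measured value. For the measured compounds named here, compound 2 therefore holds no clear rank: the only measured step of a 1.7-fold lower number from compound 1 to compound 2 (0.24 log units; within the scatter) stays within the usual scatter, so the two numbers cannot be told apart. That step put nitro in place of hydrogen on an aromatic carbon.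

Compound 3 `CCOc1ccc2nc(NC(=O)CCCCCCC(=O)NO)sc2c1` has not been measured yet. Going by the values given here, its only difference from compound 2 is ethoxy in place of nitro on an aromatic carbon, in detail ethoxy in place of nitro on an aromatic carbon with the rest of the structure unchanged. Among the compounds with values here, no compound carrying ethoxy has a number yet, so the evidence is thin. Within the data shown here, the one step that bears on this change is the nitro step a 1.7-fold lower number from compound 1 to compound 2 (0.24 log units; within the scatter) which stayed within the scatter, so no step beyond the scatter is expected in this assay when nitro leaves and ethoxy enters. The estimated step of a 1.3-fold higher number from compound 2 to compound 3 (0.12 log units; within the scatter) is expected to stay within the scatter. Compound 3 is expected to give about 5 ug/mL with an estimated range from 2.5 ug/mL to 10 ug/mL in this measurement.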

Compound 3, half-maximal inhibitory concentration: 11.6 ug/mL
Beside the measured number, compound 3's estimate is 2.3-fold (0.37 log units) below it, and the stated range ends below it.
By their numbers in this assay, from the lowest: compounds 2, 1 and 3 (each within the scatter of the next, the first and the last beyond it).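

At this position on the six-membered aromatic ring, the choice of group now makes a measurable difference in this assay, with a 3.0-fold higher number from compound 2 to compound 3 (0.48 log units; beyond the scatter) as a modest step beyond the scatter. Neither group can be separated from plain hydrogen, however: a 1.7-fold lower number from compound 1 to compound 2 (0.24 log units; within the scatter) and a 1.8-fold higher number from compound 1 to compound 3 (0.24 log units; within the scatter) both stay within the scatter, so the only clear gap in this set lies between nitro and ethoxy, the two ends of the short series, with the unsubstituted compound 1 not distinguishable from either. Nitro and ethoxy each have 3 heavy atoms, so the count of heavy atoms alone does not separate compound 2 from compound 3, even though their numbers differ beyond the scatter.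

No measurement at hand explains the gap between nitro and ethoxy. From the compounds shown here alone, it also remains open where other groups at this position would fall relative to these three compounds, for example an amine, a carboxylic acid or a longer chain such as butoxy, and whether any of them would move clearly away from compound 1.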